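Aryl variation on the hydrazone carbon: outlook for compound 3

The compounds below may be only part of what the source reports. "The series", "measured", "known", "first", "only" and "open" are said of these compounds alone.

Measured so far in a functional assay on A549 cells (Homo sapiens) for cytotoxicity, read by MTT assay, with a stated time of 72 h; a higher number here means a weaker inhibitor, a lower number a stronger inhibitor:
compound 1 `COc1ccc(/C=N/NC(=O)Nc2ccc(Oc3ccnc(-c4nncn4CCN(C)C)c3)c(F)c2)c(OC)c1`: 2820 nM
compound 2 `CN(C)CCn1cnnc1-c1cc(Oc2ccc(NC(=O)N/N=C/c3ccccc3)cc2F)ccn1`: 1860 nM

Compound 2 and compound 1 differ only in the aryl group on the carbon with a double bond to nitrogen, and the step of a 1.5-fold lower number from compound 1 to compound 2 (0.18 log units; within the scatter) stays within the scatter, so the two values cannot be ordered; compound 2 simply sits at the lower of the two numbers. Compound 3 `CN(C)CCn1cnnc1-c1cc(Oc2ccc(NC(=O)N/N=C/c3ccc(F)cc3F)cc2F)ccn1` is unmeasured in this assay. It differs from compound 2 as 2,4-difluorophenyl in place of phenyl on a carbon with a double bond to nitrogen. For the measured compounds named here, the only step bearing on this position is a 1.5-fold lower number from compound 1 to compound 2 (0.18 log units; within the scatter), which shows that replacing one aryl group on this carbon with another moved the number no further than the scatter. Going by the values given here, no other step at this position exists. The expectation for compound 3 is therefore a change of a 1.1-fold higher number from compound 2 to compound 3 (0.03 log units; within the scatter), within the scatter, in either direction. Compound 3 is estimated at 2000 nM, with a range from 900 nM to 4500 nM.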

Compound 3, half-maximal inhibitory concentration: 1870 nM
Beside the measured number, compound 3's estimate is 1.1-fold (0.03 log units) above it, and the stated range covers the measured number.
By their numbers in this assay, from the lowest: compounds 2, 3 and 1 (each within the scatter of the next).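

In this assay, 2,4-difluorophenyl and phenyl on the carbon with a double bond to nitrogen cannot be told apart, with a 1.0-fold higher number from compound 2 to compound 3 (0.00 log units; within the scatter) as the step. The same holds against 2,4-dimethoxyphenyl, with a 1.5-fold lower number from compound 1 to compound 3 (0.18 log units; within the scatter) as the step, so a fluorine-bearing aryl group now joins the unsubstituted and methoxy-bearing ones, and all three compounds lie within the scatter of one another. No supporting data are available to explain this result.

On these data alone, whether an aryl group carrying an amine or a carboxylic acid would stay within this range remains open. As far as these compounds go, it is also open whether this holds when a saturated ring or a longer chain stands on this carbon in place of the aryl group.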